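The source may report more compounds than this note shows. Statements on the series, on what has been measured and on what is new or still open speak of the compounds shown alone.

Measured so far in the series:

compound 1, `N#Cc1c(-c2ccco2)[n+]([O-])c2ccccc2[n+]1[O-]`: 0.582
compound 2, `N#Cc1c(-c2ccco2)[n+]([O-])c2ccc(Cl)cc2[n+]1[O-]`: 1.11
compound 3, `Cc1ccc(-c2c(C#N)[n+]([O-])c3cc(Cl)ccc3[n+]2[O-])cc1`: 2.6

All three numbers come from a physicochemical assay for lipophilicity, measured as octanol-water partition; on this read-out lower numbers stand for lower lipophilicity and higher numbers for higher lipophilicity. Within the measured set the only two single-point comparisons are these: a number 0.53 log units higher from compound 1 to compound 2 (beyond the scatter), a modest step for chloro in place of hydrogen on an aromatic carbon; and a number 1.49 log units higher from compound 2 to compound 3 (beyond the scatter), a large step for 4-methylphenyl in place of furan-2-yl on an aromatic carbon. Compound 3 thus gives the highest number of the three in this assay, with compound 2 nearest and compound 1 furthest, both gaps beyond the scatter. Compound 1 and compound 3 differ in more than one place, so the difference between the two cores is not broken down here.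

Not yet measured is compound 4, `Cc1ccc(-c2c(C#N)[n+]([O-])c3cc(Cl)c(Cl)cc3[n+]2[O-])cc1`. Relative to compound 3 the change is chloro in place of hydrogen on an aromatic carbon. Going by the values given here, this is the same kind of change as the one from compound 1 to compound 2, (chloro in place of hydrogen on an aromatic carbon), but not the same: in compound 4 the entering chloro sits ortho to a chloro group, whereas in compound 2 it does not. The expectation for compound 4 rests on compound 1 and compound 2, where this kind of change gave a number 0.53 log units higher from compound 1 to compound 2 (beyond the scatter). On that basis the step expected in this assay is a number 0.50 log units higher from compound 3 to compound 4 (beyond the scatter), close to the earlier one, with some allowance for the different surroundings. Compound 4 is therefore expected to give about 3.1 in this assay, most likely between 2.7 and 3.5.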

Compound 4, partition coefficient: 3.1
Estimate against measurement, compound 4: no gap at the digits printed; measured number inside the range.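

In this assay, chloro in place of hydrogen on an aromatic carbon gives a number 0.50 log units higher from compound 3 to compound 4 (beyond the scatter), and the same kind of change on the core of compound 1 gives a number 0.53 log units higher from compound 1 to compound 2 (beyond the scatter), so the two steps are close in size across two cores, one carrying furan-2-yl and the other 4-methylphenyl. Going by these compounds alone, this is only two pairs, however, and the cores differ in more than the aryl group at that carbon: in compound 4 the entering chloro is ortho to a chloro group, whereas in compound 2 it is not, so the agreement cannot be assigned to either difference alone and does not establish a general rule for the series. Nothing at hand explains why the two steps are so alike.

The compounds shown leave open whether the step would hold for a chloro entering the 4-methylphenyl core with no chloro group already on that ring, or on cores bearing other aryl groups. They also leave open how other groups at the same aromatic carbon, such as a fluoro, a methoxy, an amine or a carboxylic acid, would compare with chloro in this read-out.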